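This account rests on a few compounds, and the source may have more. Where it says the series, first, only, none or still open, it means among the compounds named here.

Measured compounds in an assay on CHO cells for displacement of a labelled ligand from adenosine receptor A3 (Homo sapiens), read by scintillation counting, tested at 1 uM; a lower number here means less inhibition, a higher number more inhibition at the concentration tested (going by the name of the read-out):
compound 1, `CC(C)c1nc(N)c2nn(-c3ccccc3)cc2n1`, gives 11%
compound 2, `Nc1nc(Cc2ccccc2Cl)nc2cn(-c3ccccc3)nc12`, gives 22%
compound 3, `Nc1nc(Cc2ccc(Cl)cc2)nc2cn(-c3ccccc3)nc12`, gives 11%

Compound 3 stands level with compound 1 at the digits shown, the two together at the low end of the three numbers. Among the measured compounds shown here, the only step that sets it apart is a number 11 percentage points lower from compound 2 to compound 3 (beyond the scatter), while no change at the digits printed from compound 1 to compound 3 (within the scatter). Compound 4, `Nc1nc(Cc2ccc(O)cc2)nc2cn(-c3ccccc3)nc12`, is not yet measured. It differs from compound 3 by hydroxy in place of chloro on an aromatic carbon. For the measured compounds named here, no measured step exchanges a chloro for a hydroxy, so the steps that bear on it are indirect: no change at the digits printed from compound 1 to compound 3 (within the scatter) and a number 11 percentage points lower from compound 2 to compound 3 (beyond the scatter) show that changes at the benzyl move this read-out little or modestly, and a number 11 percentage points higher from compound 1 to compound 2 (beyond the scatter) is of the same modest size. Nothing in these numbers speaks for a shift beyond the scatter in this assay in either direction. The step expected in this assay is therefore no change at the digits printed from compound 3 to compound 4 (within the scatter). Compound 4 is accordingly estimated at 11%, with a range from 0% to 25%.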

Compound 4, a percentage reported as inhibition, at one concentration (the size of the read-out at that concentration, not a potency): 20%
For compound 4 the middle estimate is 9 percentage points below the measured one; the range from low to high includes it.
By their numbers in this assay, from the lowest: compounds 1, 3, 4 and 2 (each within the scatter of the next, the first and the last beyond it).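

In this assay, among the compounds shown here, the first exchange on this carbon, para to a large group, gives a number 9 percentage points higher from compound 3 to compound 4 (within the scatter) and so brings in a hydrogen-bond donor and a hydrogen-bond acceptor without a step beyond the scatter. The 4-hydroxybenzyl group reads with both other side groups, showing a number 2 percentage points lower from compound 2 to compound 4 (within the scatter) and also a number 9 percentage points higher from compound 1 to compound 4 (within the scatter) even though the earlier pair shows a number 11 percentage points higher from compound 1 to compound 2 (beyond the scatter) and stands apart. For the compounds shown here, at this carbon, this assay so far does not separate chloro from hydroxy.

Still open is whether an amine, a methoxy or a carboxylic acid on the same carbon would give a step beyond the scatter, and a reading at one concentration gives no potency for any of these compounds. No measurement shown here bears on why hydroxy and chloro read as they do.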